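This account rests on a few compounds, and the source may have more. Where it says the series, first, only, none or still open, it means among the compounds named here.

Working notes on the series.

Compound 3 `Cc1ccc(Cn2cc(CSc3nc(Nc4ccc(C)cc4)c(C#N)c(-c4ccccc4)n3)nn2)cc1` is known in a functional assay on MCF7 cells (Homo sapiens) for inhibition, read by MTT assay, with a stated time of 72 h (on this read-out higher numbers stand for weaker inhibition and lower numbers for stronger inhibition), only as a limit: in this assay compound 3 gives > 64000 nM, a limit of the assay and not a number. Compound 2 `Cc1ccc(Nc2nc(SCc3cn(Cc4ccc(Cl)cc4)nn3)nc(-c3ccccc3)c2C#N)cc1` sits at the same limit; in this assay compound 2 gives > 64000 nM, again a limit and not a number. Within the data shown here, the one step the measured compounds offer on this stretch, a step that the two limits leave unreadable from compound 2 to compound 3, is therefore not readable, because both ends sit at the limit of > 64000 nM in this assay, at which 2 of the 3 values shown sit. Among the measured compounds shown here, compound 1 `N#Cc1c(Nc2cccc(C(F)(F)F)c2)nc(SCc2cn(Cc3ccccc3Cl)nn2)nc1-c1ccccc1` is the only one with a number; in this assay compound 1 gives 12600 nM.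

Compound 4 `Cc1ccc(Nc2nc(SCc3cn(Cc4ccccc4Cl)nn3)nc(-c3ccccc3)c2C#N)cc1` differs from compound 3 by 2-chlorophenyl in place of 4-methylphenyl on a saturated chain carbon bound to an aromatic nitrogen. For the measured compounds named here, no measured step covers this change on the core of compound 3, so the size in this assay cannot be taken from the measured pairs. Going by the values given here, compound 4 carries the same 2-chlorobenzyl as compound 1, whose value of 12600 nM is the only number in the set. Compound 4 is expected to lie between that number and the limit, estimated at 40000 nM, range 12000 nM to 90000 nM, which as a step reads an at least 1.6-fold lower number from compound 3 to compound 4 (0.20 log units; that floor lies within the scatter) and is expected rather than measured.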

Compound 4, half-maximal inhibitory concentration: 9420 nM
Beside the measured number, compound 4's estimate is 4.2-fold (0.63 log units) above it; measured number below the stated range.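

In this assay, the group on the saturated chain carbon bound to an aromatic nitrogen now has a readable effect: 2-chlorophenyl in place of 4-methylphenyl gives an at least 6.7-fold lower number from compound 3 to compound 4 (0.83 log units; beyond the scatter), and 2-chlorophenyl in place of 4-chlorophenyl gives an at least 6.7-fold lower number from compound 2 to compound 4 (0.83 log units; beyond the scatter). The second change keeps the chlorine and moves it from the 4-chlorophenyl to the 2-chlorophenyl arrangement, so among these compounds the presence of chlorine alone does not account for the step. With 2-chlorobenzyl held, 4-methylphenyl in place of 3-(trifluoromethyl)phenyl on a nitrogen on an aromatic ring gives a 1.3-fold lower number from compound 1 to compound 4 (0.13 log units; within the scatter), so this change shows no readable difference.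

Still open, from the compounds shown here alone, is whether a methoxy group or an amine in place of the chlorine of the 2-chlorophenyl would hold the number of compound 4. The step from compound 2 to compound 3 still cannot be read, because both ends sit at a limit: the limit of > 64000 nM in this assay, at which 2 of the 4 values shown sit.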